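Compound 1 to compound 3: a carbonyl-bearing replacement

The compounds below may be only part of what the source reports. "The series", "measured", "known", "first", "only" and "open" are said of these compounds alone.

Measured so far in a functional assay on A549 cells (Homo sapiens) for antiproliferative activity, read by MTT assay, with a stated time of 24 h (a lower number here means a stronger inhibitor, a higher number a weaker inhibitor), are these two compounds:
- compound 1 `O=C(NNc1ccccc1Cl)c1ccccc1NS(=O)(=O)c1cnc(O)nc1O` gives 5480 nM in this read-out
- compound 2 `O=C(NNC(=O)c1cccc(NS(=O)(=O)c2cnc(O)nc2O)c1)c1cccc(Cl)c1` gives 6000 nM in this read-out

Compound 1 stands level with compound 2 on these numbers. The two values lie within the usual scatter of each other, so neither can be ranked ahead in this assay on this evidence.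

Compound 3 `Cc1ccccc1C(=O)NNC(=O)c1ccccc1NS(=O)(=O)c1cnc(O)nc1O` has not yet been measured. It carries (2-methylphenyl)carbonyl in place of 2-chlorophenyl on an amine nitrogen and otherwise matches compound 1.

Going by the values given here, no measured pair isolates this change, so the data give no direct size for it. Among the compounds with values here, the only guide is the narrow spread of the two values in hand. A small move toward a higher number is expected, possibly nothing beyond the scatter. The estimate is a 1.2-fold higher number from compound 1 to compound 3 (0.07 log units; within the scatter) as an expected step, not a measured one.

Compound 3 is expected at 6500 nM within an estimated range of 2500 nM to 17000 nM as the working figures.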

Compound 3, half-maximal inhibitory concentration: 5450 nM
Compound 3: the middle estimate sits 1.2-fold (0.08 log units) above what was measured; measured number inside the range.
By their numbers in this assay, from the lowest: compounds 3, 1 and 2 (each within the scatter of the next).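

In this assay, going by these compounds alone, (2-methylphenyl)carbonyl in place of 2-chlorophenyl on an amine nitrogen gives a 1.0-fold lower number from compound 1 to compound 3 (0.00 log units; within the scatter), the first measured step that isolates a change in one place. At this position, the two groups cannot be told apart in this read-out, even though the entering group is larger by heavy-atom count and brings a carbonyl with a hydrogen-bond acceptor where the leaving group has none. No supporting measurement bears on why this exchange leaves the two compounds level.

The step combines two differences, the added carbonyl and the methyl group standing where the chlorine stood, and compound 1 and compound 3 alone cannot show whether each would be as silent without the other. Also open, on these data alone, is whether this position would remain as undiscriminating with a group of a different kind, such as a carboxylic acid, an amine or a longer alkyl chain, in place of 2-chlorophenyl.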